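The source may report more compounds than this note shows. Statements on the series, on what has been measured and on what is new or still open speak of the compounds shown alone.

Measured so far:
compound 1 `CC(=O)Oc1c(O)cc2oc(-c3ccccc3)cc(=O)c2c1O` — 11000 nM
compound 2 `CC(=O)Oc1cc2oc(-c3ccccc3)cc(=O)c2c(O)c1OC(C)=O` — 9700 nM

In a functional assay on KB 3-1 cells (Homo sapiens), with a stated time of 1 h (on this read-out lower numbers stand for an effect already at smaller amounts and higher numbers for an effect only at larger amounts of compound), compound 1 gives 11000 nM and compound 2 gives 9700 nM; the two lie within the scatter of each other, so compound 2 does not stand apart. For the measured compounds named here, the one measured step, a 1.1-fold lower number from compound 1 to compound 2 (0.05 log units; within the scatter), shows that acetyl in place of hydrogen on an oxygen on an aromatic ring left the read-out unchanged. Compound 3 `CC(=O)Oc1cc2oc(-c3ccccc3)cc(=O)c2c(OCc2ccccc2)c1OC(C)=O` carries benzyl in place of hydrogen on an oxygen on an aromatic ring. Going by the values given here, no measured step covers a benzyl group; the only guide is that the one change so far at such an oxygen made no difference. The expected step is a 1.1-fold lower number from compound 2 to compound 3 (0.03 log units; within the scatter), none beyond the scatter. Compound 3 is estimated at 9000 nM, between 3000 nM and 30000 nM.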

Compound 3, half-maximal effective concentration: 3700 nM
Compound 3: the middle estimate sits 2.4-fold (0.39 log units) above what was measured, within the range that was stated.
By their numbers in this assay, from the lowest: compound 3; then compounds 2 and 1 (each within the scatter of the next).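

In this assay, benzyl in place of hydrogen on an oxygen on an aromatic ring gives a 2.6-fold lower number from compound 2 to compound 3 (0.42 log units; beyond the scatter), a modest step beyond the scatter, while the acetyl change, a 1.1-fold lower number from compound 1 to compound 2 (0.05 log units; within the scatter), stayed within it. At this oxygen, the change from hydroxy to benzyloxy therefore moves the read-out to a lower number. Nothing available explains this shift.

Open, going by these compounds, is whether the step needs the benzyl ring or would also follow from a methyl group or a longer chain at this oxygen. Also open, on these data alone, is how an amine or a carboxylic acid on the benzyl ring would read.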